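The source may hold more compounds than are shown below. What is called first, only, known or untested is meant among the compounds shown, and "the series" means these compounds.

Of the compounds shown here, three of a shared core have been measured in an assay on membranes from brain for displacement of a labelled ligand from metabotropic glutamate receptor 5 (Rattus norvegicus); on this read-out higher numbers stand for weaker inhibition and lower numbers for stronger inhibition. Compound 1 `Cc1cccc(NC(=O)c2nccn2C)n1` gives 3070 nM; compound 2 `Cc1cccc(NC(=O)c2cc(-c3ncccn3)ccn2)n1` gives 2480 nM; compound 3 `Cc1cccc(NC(=O)c2ccc(-c3ccccc3)cn2)n1` gives 2800 nM. Compound 3 thus stands second highest of the three numbers, though its gaps to compound 1 and to compound 2 both fall within the scatter, so no order among them can be claimed. Compound 4 `Cc1cccc(NC(=O)c2ccc(-c3ccccn3)cn2)n1` differs from compound 3 in one place: pyridin-2-yl in place of phenyl on an aromatic carbon. Among the measured compounds shown here, no measured pair in this set shows such an exchange, so nothing here indicates a step beyond the scatter in either direction. Compound 4 is therefore expected to stay close to compound 3, with an estimated step of a 1.1-fold lower number from compound 3 to compound 4 (0.05 log units; within the scatter). For compound 4 the estimate is 2500 nM, with a range from 900 nM to 7000 nM.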

Compound 4, inhibition constant: 100 nM
The estimate for compound 4 lay 25-fold (1.40 log units) above the measured number; the whole stated range lies above it.
By their numbers in this assay, from the lowest: compound 4; then compounds 2, 3 and 1 (each within the scatter of the next).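

In this assay, pyridin-2-yl in place of phenyl on this aromatic carbon gives a 28-fold lower number from compound 3 to compound 4 (1.45 log units; beyond the scatter), a large step. The earlier compounds shown here offered no pair differing in one place, whereas this one shows that the position responds strongly to an exchange that keeps the heavy-atom count and brings in a hydrogen-bond acceptor. Nothing available explains the size of this step. The compounds shown leave open whether the step depends on where the nitrogen sits in the ring, as with pyridin-3-yl or pyridin-4-yl, and how a non-aromatic amine such as morpholine would fare at this carbon.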